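Two stereo changes on a shared kinase inhibitor core

The source may report more compounds than this note shows. Statements on the series, on what has been measured and on what is new or still open speak of the compounds shown alone.

Compound 1: `Cc1cccc(C)c1S(=O)(=O)N1CCC[C@H]1[C@@H](O)CN1CCC[C@@]2(CCN(c3ncnc(N)c3C3CC3)C2)C1` — 9 nM
Compound 2: `Cc1cccc(C)c1S(=O)(=O)N1CCC[C@H]1[C@H](O)CN1CCC[C@@]2(CCN(c3ncnc(N)c3C3CC3)C2)C1` — 250 nM

In an assay on isolated protein for inhibition of RAC-alpha serine/threonine-protein kinase (Homo sapiens) (a higher number here means a weaker inhibitor, a lower number a stronger inhibitor), compound 1 gives 9 nM, and compound 2 gives 250 nM. Compound 2 stands at the higher of the two numbers, and the step of a 28-fold higher number from compound 1 to compound 2 (1.44 log units; beyond the scatter) was large, resting on nothing more than the fact that compounds 1 and 2 differ only in the configuration as drawn. Compound 3 is `Cc1cccc(C)c1S(=O)(=O)N1CCC[C@@H]1[C@@H](O)CN1CCC[C@@]2(CCN(c3ncnc(N)c3C3CC3)C2)C1`. It keeps every atom and bond of compound 2 and differs only in configuration: the two compounds have the same atoms and bonds and differ only in configuration as drawn: 2 of 3 stereo elements differ; a stereocentre at a saturated ring carbon is drawn S in compound 2 and R in compound 3; a stereocentre at a saturated chain carbon is drawn R in compound 2 and S in compound 3. Among the compounds with values here, the only measured step that bears on this change is the one from compound 1 to compound 2, where a single chain stereocentre moved the number by a large amount; here two centres move at once, one of them the ring carbon, for which no comparison exists. The account therefore expects that configuration matters again, but cannot fix the direction with confidence. The estimate for compound 3 is 60 nM, within 8 nM to 500 nM, which would mean an expected step of a 4.2-fold lower number from compound 2 to compound 3 (0.62 log units; beyond the scatter).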

Compound 3, half-maximal inhibitory concentration: 19 nM
Estimate against measurement, compound 3: 3.2-fold (0.50 log units) above; low and high end bracket the measured number.
By their numbers in this assay, from the lowest: compound 1; then compound 3; then compound 2.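

The ring stereocentre now has a comparison of its own in this assay, with a 2.1-fold higher number from compound 1 to compound 3 (0.32 log units; beyond the scatter), and configuration is the only thing that separates the pair: the fact that compounds 1 and 3 differ only in the configuration as drawn. That step is modest, while the single change at the chain stereocentre gave the large 28-fold higher number from compound 1 to compound 2 (1.44 log units; beyond the scatter), so among these compounds the configuration of the chain carbon moves the number more than that of the ring carbon. Within the data shown here, the other new step, a 13-fold lower number from compound 2 to compound 3 (1.12 log units; beyond the scatter), is also large, but it changes both centres at once, so it cannot be divided between them; taken with the two single changes, it shows only that the two compounds with the chain carbon drawn S both give lower numbers than the one with it drawn R.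

What the chain stereocentre does when the ring carbon is drawn R stays open, as the single-centre comparisons shown start from one configuration only. Also open, going by these compounds, is whether the gap between the two chain configurations depends on the hydroxyl itself, or would persist with an amine in its place.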